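A few compounds are considered here, and "the series" means these few. Any claim that something is new, unique, unknown or untested is made for them only; others in the source may bear on it.

Measured so far:
- compound 1, `CCCOC(=O)Nc1ccc([Se]C#N)cc1`: 9100 nM
- compound 2, `CCOC(=O)Nc1ccc([Se]C#N)cc1`: 18600 nM
- compound 3, `CC(C)COC(=O)Nc1ccc([Se]C#N)cc1`: 21600 nM

These three share one core and differ only in the carbamate chain. In an ADME assay on 184B5 cells (Homo sapiens) for cytotoxicity, read by MTT assay, with a stated time of 72 h (on this read-out higher numbers stand for weaker inhibition of growth and lower numbers for stronger inhibition of growth), compound 3 gives the highest of the three numbers; its gap to compound 2 is within the scatter, while compound 1 sits well apart, as a 2.4-fold higher number from compound 1 to compound 3 (0.38 log units; beyond the scatter) shows. Compound 4, `CCCCOC(=O)Nc1ccc([Se]C#N)cc1`, is not yet measured. It differs from compound 3 by propyl in place of isopropyl on a saturated chain carbon bound to an oxygen next to a carbonyl group, so the chain is straightened without changing its size.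

Among the measured compounds shown here, two measured steps bear on this. The step of a 1.2-fold higher number from compound 2 to compound 3 (0.06 log units; within the scatter) shows that changing the group on the saturated chain carbon bound to an oxygen next to a carbonyl group made little difference. The step of a 2.0-fold higher number from compound 1 to compound 2 (0.31 log units; beyond the scatter), however, shows that a longer straight chain went with a lower number. Compound 4 carries the longest straight chain of the set, so the expected step is roughly a 2.2-fold lower number from compound 3 to compound 4 (0.33 log units; beyond the scatter) in this assay. Compound 4 is therefore estimated at 10000 nM, within 4500 nM to 22000 nM.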

Compound 4, concentration for total growth inhibition: 14500 nM
For compound 4 the middle estimate is 1.5-fold (0.16 log units) below the measured one, and the stated range covers the measured number.
By their numbers in this assay, from the lowest: compounds 1, 4, 2 and 3 (each within the scatter of the next, the first and the last beyond it).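

Straightening the chain at this position, with propyl in place of isopropyl, gives a difference within the scatter in this assay (a 1.5-fold lower number from compound 3 to compound 4 (0.17 log units; within the scatter)), so the branch in this chain shows no clear effect of its own. The butyl chain of compound 4 also stays within the scatter of the two shorter straight chains (a 1.3-fold lower number from compound 2 to compound 4 (0.11 log units; within the scatter); a 1.6-fold higher number from compound 1 to compound 4 (0.20 log units; within the scatter)), so the gap between compound 1 and compound 2 does not grow into a steady trend with chain length across these straight chains. Nothing measured here offers an explanation for these results.

Still open, from the compounds shown here alone, is whether a longer chain such as hexyl, or a ring such as cyclohexyl or benzyl, would give a step beyond the scatter. Going by these compounds, how an amine or a carboxylic acid at the end of the chain would read also remains unknown.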